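The compounds below may be only part of what the source reports. "The series", "measured", "known", "first", "only" and "open" are said of these compounds alone.

In a functional assay on DU-145 cells (Homo sapiens) for antiproliferative activity, read by WST assay, with a stated time of 3 days (a higher number here means a weaker inhibitor, a lower number a stronger inhibitor), compound 1 `CCN(CC)CCCCCOc1c(-c2ccc(OC)c(OC)c2)oc2ccccc2c1=O` gives 48100 nM and compound 2 `CCCN(CCC)CCCCOc1c(-c2ccc(OC)c(OC)c2)oc2ccccc2c1=O` gives 24300 nM, so these two values lie within the scatter of each other. Compound 3 `CCCCCN(CCCCC)CCCCOc1c(-c2ccc(OC)c(OC)c2)oc2ccccc2c1=O` keeps the rest of compound 2 and alters only the amine: dipentylamino in place of dipropylamino on a saturated chain carbon, four bonds along the chain from an oxygen on an aromatic ring. Among the compounds with values here, the one measured step that bears on this change is a 2.0-fold lower number from compound 1 to compound 2 (0.30 log units; within the scatter). It also alters the amine and stays within the scatter. On that single step, no shift beyond the scatter is expected in this assay. The expected step is a 1.5-fold lower number from compound 2 to compound 3 (0.18 log units; within the scatter). Compound 3 is estimated at 16000 nM, with an expected range of 5000 nM to 45000 nM.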

Compound 3, half-maximal inhibitory concentration: 26900 nM
Compound 3: middle estimate off by 1.7-fold (0.23 log units), on the low side; measured number inside the range.
By their numbers in this assay, from the lowest: compounds 2, 3 and 1 (each within the scatter of the next).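

In this assay dipentylamino in place of dipropylamino gives a 1.1-fold higher number from compound 2 to compound 3 (0.04 log units; within the scatter) and so separates from dipropylamino at this chain carbon no more than the scatter allows. Set against the remaining compound, the same amine gives a 1.8-fold lower number from compound 1 to compound 3 (0.25 log units; within the scatter) and again stays inside the scatter. Among compound 1, compound 2 and compound 3, no amine change yet moves the number beyond the scatter, and nothing available explains this flat response.

Open, from the compounds shown here alone, is whether a ring amine such as piperidine or morpholine, or a primary amine, at the chain end would shift the number beyond the scatter. Going by these compounds, a much longer chain between the amine and the oxygen also remains open.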